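Ester variation on the shared core: cyclohexylethyl to pyridinylethenyl

The source may hold more compounds than are shown below. What is called first, only, known or untested is meant among the compounds shown, and "the series" means these compounds.

Two compounds of the series have numbers in an ADME assay on HepG2 2.2.15 cells (Homo sapiens) for cytotoxicity; on this read-out higher numbers stand for lower toxicity in this test and lower numbers for higher toxicity in this test. Compound 1 `C=CCn1c(=O)c(CCO)c(-c2ccccc2Cl)c2cc(Cl)ccc21` gives 23000 nM. Compound 2 `O=C(CCC1CCCCC1)OCCc1c(-c2ccccc2Cl)c2cc(Cl)ccc2[nH]c1=O`, which carries an ester on the hydroxyethyl chain of the core, gives 160000 nM; this is the higher of the two numbers, and the gap to compound 1 lies beyond the usual scatter. Compound 3 `O=C(/C=C/c1cccnc1)OCCc1c(-c2ccccc2Cl)c2cc(Cl)ccc2[nH]c1=O` keeps the ester and changes only its acyl part: 2-(pyridin-3-yl)ethenyl in place of 2-cyclohexylethyl on a carbonyl carbon. Among the measured compounds shown here, no measured pair shows this kind of exchange, so the size of the step is open. The expectation is a modest move from compound 2 to compound 3 towards a lower number, estimated as a 1.6-fold lower number from compound 2 to compound 3 (0.20 log units; within the scatter), with the possibility that the change stays within the scatter. On that basis compound 3 is expected to give about 100000 nM in this assay, with a range from 30000 nM to 300000 nM.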

Compound 3, half-maximal cytotoxic concentration: 39000 nM
Compound 3: the middle estimate sits 2.6-fold (0.41 log units) above what was measured; the range from low to high includes it.
By their numbers in this assay, from the lowest: compounds 1 and 3 (each within the scatter of the next); then compound 2.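

In this assay the acyl part of the ester on the shared core affects the read-out: 2-(pyridin-3-yl)ethenyl in place of 2-cyclohexylethyl on a carbonyl carbon gives a 4.1-fold lower number from compound 2 to compound 3 (0.61 log units; beyond the scatter) in a single exchange. The two groups have the same number of heavy atoms, yet the exchange replaces a non-aromatic carbon ring with an aromatic ring with 1 hetero atom and adds a double bond outside aromatic rings and a hydrogen-bond acceptor. Nothing at hand bears on the reason for this step.

Which of these differences carries the step stays open, since this pair changes them together. The question remains how 2-phenylethenyl or 2-(pyridin-3-yl)ethyl on the same carbonyl carbon would compare with compound 2 and compound 3 in this assay.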